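The source may report more compounds than this note shows. Statements on the series, on what has been measured and on what is new or still open speak of the compounds shown alone.

Compound 1 `Nc1ccccc1NC(=O)c1ccc(Cn2cnc3c(Nc4cccc(OC(F)(F)F)c4)nc(Cl)nc32)cc1` gives 62.4% in a functional assay on NCI-H460 cells (Homo sapiens) for antiproliferative activity, read by CCK-8 assay, with a stated time of 72 h, tested at 8 uM (a lower number here means a weaker effect, a higher number a stronger effect of the compound at the concentration tested), and stands second highest of the three numbers; compound 2 `CC(C)n1cnc2c(Nc3cccc(Cl)c3)nc(NCOCc3ccc(/C=C/C(=O)Nc4ccccc4N)cc3)nc21` gives 61.1% and compound 3 `Nc1ccccc1NC(=O)/C=C/c1ccc(Cn2cnc3c(Nc4cccc(OC(F)(F)F)c4)nc(Cl)nc32)cc1` gives 66.7%, both within the scatter of compound 1. Among the compounds with values here, the one measured step, a number 4.3 percentage points higher from compound 1 to compound 3 (within the scatter), puts 2-((2-aminophenyl)carbamoyl)ethenyl in place of (2-aminophenyl)carbamoyl and is within the scatter. Compound 4 `Nc1ccccc1NC(=O)c1ccc(Cn2cnc3c(Nc4cccc(Cl)c4)nc(Cl)nc32)cc1` differs from compound 1 by chloro in place of trifluoromethoxy on an aromatic carbon. Within the data shown here, no measured step covers this change; compound 2 also carries a (3-chlorophenyl)amino group but differs from compound 1 elsewhere as well, and its value only shows a number close to that of compound 1. For compound 4 a step of a number 2.4 percentage points lower from compound 1 to compound 4 (within the scatter) is therefore expected, not beyond the scatter. Compound 4 is estimated at 60%, ranging from 48% to 72%.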

Compound 4, a percentage reported as inhibition, at one concentration (the size of the read-out at that concentration, not a potency): 67%
Beside the measured number, compound 4's estimate is 7 percentage points below it, and the stated range covers the measured number.
By their numbers in this assay, from the lowest: compounds 2, 1, 3 and 4 (each within the scatter of the next).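

At the aromatic carbon meta to a large group, a number 4.6 percentage points higher from compound 1 to compound 4 (within the scatter) in this assay for chloro in place of trifluoromethoxy. The 3-chlorophenyl and 3-(trifluoromethoxy)phenyl versions therefore cannot be told apart at this single concentration, and this position accepts either group on the shared core of compound 1 and compound 4. Nothing available gives a reason for this result.

From the compounds shown here alone, whether an amine or a carboxylic acid at this position would stay within the scatter remains open. So does whether chloro in place of trifluoromethoxy gives a similar result on compound 3.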